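The compounds below may be only part of what the source reports. "The series", "measured", "known", "first", "only" and "open" are said of these compounds alone.

Within the data shown here, compound 2 `O=C(Nc1ccc(Cl)cc1)c1cccc(N2C(=O)N/C(=C\c3ccc(O)cc3)C2=O)c1` gives 125000 nM in a functional assay on NCI-H292 cells (Homo sapiens) for antiproliferative activity (a higher number here means a weaker inhibitor, a lower number a stronger inhibitor), the only plain number in this small set. Compound 1 `O=C1N/C(=C\c2ccc(O)cc2)C(=O)N1c1cccc(I)c1` gives only a limit, > 200000 nM; this is the limit of > 200000 nM in this assay, at which 1 of the 2 values shown sits. Among the measured compounds shown here, the single measured step, an at least 1.6-fold lower number from compound 1 to compound 2 (0.20 log units; that floor lies within the scatter), concerns a different change and offers little guidance. Compound 3 `O=C(NCc1ccccc1)c1cccc(N2C(=O)N/C(=C\c3ccc(O)cc3)C2=O)c1` carries benzyl in place of 4-chlorophenyl on an amide-type nitrogen. For the measured compounds named here, no measured step tests this swap, so no shift beyond the scatter is expected in either direction. The expected step of no change at the digits printed from compound 2 to compound 3 (within the scatter) is accordingly small. Compound 3 is estimated at 125000 nM, with a range from 40000 nM to 400000 nM.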

Compound 3, half-maximal inhibitory concentration: 23500 nM
The estimate for compound 3 lay 5.3-fold (0.73 log units) above the measured number, outside the stated range (below it).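

In this assay, benzyl in place of 4-chlorophenyl on the amide-type nitrogen gives a 5.3-fold lower number from compound 2 to compound 3 (0.73 log units; beyond the scatter), so this group matters even though both hold one six-membered aromatic ring of carbon only. Benzylcarbamoyl in place of iodo on an aromatic carbon gives an at least 8.5-fold lower number from compound 1 to compound 3 (0.92 log units; beyond the scatter). That step is only a floor, since compound 1 carries a limit and not a number: the limit of > 200000 nM in this assay, at which 1 of the 3 values shown sits.

On these data alone, whether the shift comes from losing the chlorine or from gaining the carbon stays open, as this change holds both. As far as these compounds go, how an unsubstituted phenyl or a longer phenethyl chain would behave in the same place also stays open.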